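Aryl amine in place of hexylamine on the shared core

This account rests on a few compounds, and the source may have more. Where it says the series, first, only, none or still open, it means among the compounds named here.

In a functional assay on MGC-803 cells (Homo sapiens) for cytotoxicity, read by MTT assay, with a stated time of 72 h (on this read-out lower numbers stand for stronger inhibition and higher numbers for weaker inhibition), compound 1 `CCCCCCNc1nc(SCc2ccc(C(F)(F)F)cc2)nc2ccccc12` gives 13100 nM, the lowest of the two plain numbers in hand. Compound 2 `FC(F)(F)c1ccc(CSc2nc(N3CCCCC3)c3ccccc3n2)cc1` gives 18600 nM in this assay; the step of a 1.4-fold higher number from compound 1 to compound 2 (0.15 log units; within the scatter) is within the scatter, so the two stand level. For compound 3 `COc1ccccc1Nc1nc(SCc2ccc(C(F)(F)F)cc2)nc2ccccc12` this assay reports only a limit, > 50000 nM. That limit is the mark (the limit of > 50000 nM in this assay, at which 1 of the 3 values shown sits). The step of an at least 3.8-fold higher number from compound 1 to compound 3 (0.58 log units; beyond the scatter) and the step of an at least 2.6-fold higher number from compound 2 to compound 3 (0.42 log units; beyond the scatter) both end at that limit and are at least modest.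

Compound 4 `Cc1ccccc1Nc1nc(SCc2ccc(C(F)(F)F)cc2)nc2ccccc12` has not yet been measured in this assay. It differs from compound 1 in that (2-methylphenyl in place of hexyl on a nitrogen on an aromatic ring). The step from compound 1 to compound 3 bears most directly on this change: there also a substituted phenyl replaced hexyl on the same nitrogen, 2-methoxyphenyl rather than 2-methylphenyl, and the number rose beyond the scatter to the limit. The step from compound 2 to compound 3 points the same way. A higher number is therefore expected for compound 4 in this assay, of a size at least modest, with a real chance that only a limit is returned.

Compound 4 is expected at 40000 nM in this assay, within 15000 nM to 120000 nM. The expected step of a 3.1-fold higher number from compound 1 to compound 4 (0.48 log units; beyond the scatter) is expected to mirror that earlier rise to the limit.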

Compound 4, half-maximal inhibitory concentration: 24400 nM
For compound 4 the middle estimate is 1.6-fold (0.21 log units) above the measured one; the measured number falls inside the stated range.
By their numbers in this assay, from the lowest: compounds 1, 2 and 4 (each within the scatter of the next). At a limit, above all of these: compound 3.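

In this assay, an aromatic ring on this nitrogen does not by itself raise the number: with 2-methylphenyl in place of hexyl the result is a 1.9-fold higher number from compound 1 to compound 4 (0.27 log units; within the scatter), so the two groups stand level. The same holds against the piperidin-1-yl group at this carbon, with a 1.3-fold higher number from compound 2 to compound 4 (0.12 log units; within the scatter), and compounds 1, 2 and 4 therefore form one level set despite their different amines. New here is that the group on the phenyl ring separates two otherwise identical compounds, since methyl in place of methoxy gives an at least 2.0-fold lower number from compound 3 to compound 4 (0.31 log units; beyond the scatter), a step read against the limit of compound 3: the limit of > 50000 nM in this assay, at which 1 of the 4 values shown sits.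

With the two ring substituents shown, it remains open whether the higher reading for compound 3 is specific to methoxy, or whether a plain phenyl, a 2-chlorophenyl or a 2-ethoxyphenyl group would fall with the methyl or the methoxy compound. No group shown at this place gives a number beyond the scatter below that of compound 1, and a shorter chain such as butyl or a morpholine ring would test whether one exists.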